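From a Methoxyphenyl Arm to a Thiazolyl Arm

The source may report more compounds than this note shows. Statements on the series, on what has been measured and on what is new or still open speak of the compounds shown alone.

Compound 1 `COC1=C(C)C(=O)/C(=C(O)/C=C/c2ccc(OC)cc2)C(=O)C1(C)C` and compound 2 `COC1=C(C)C(=O)/C(=C(O)/C=C/c2ccccc2OC)C(=O)C1(C)C` share one core and differ only in the aromatic group carried on the chain. In a functional assay on HUVEC cells (Homo sapiens) (a higher number here means that more compound is needed for the effect, a lower number that less compound is needed), compound 1 gives a value that is a limit of the assay, < 4 ug/mL. In this assay compound 2 likewise reaches only a limit, < 4 ug/mL. The step that the two limits leave unreadable from compound 1 to compound 2 therefore cannot be sized. Compound 2 thus stands at the limit of < 4 ug/mL in this assay, at which 2 of the 2 values shown sit, and nothing in the numbers separates it from compound 1.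

Compound 3 `COC1=C(C)C(=O)/C(=C(O)/C=C/c2nccs2)C(=O)C1(C)C` has not yet been measured. It changes compound 2 as follows: 1,3-thiazol-2-yl in place of 2-methoxyphenyl on a double-bonded chain carbon bound to a double-bonded chain carbon. For the measured compounds named here, the only measured step, from a 4-methoxyphenyl to a 2-methoxyphenyl, is unreadable, so no sized step guides the thiazolyl change; it shows only that both aromatic arms kept the effect under the limit. Compound 3 is therefore expected to stay near that limit, with the step that the limit leaves unreadable from compound 2 to compound 3 estimated as small and of unknown direction. Compound 3 is estimated at 2.5 ug/mL, between 0.6 ug/mL and 10 ug/mL, and is most likely itself reported only as a limit.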

Compound 3, concentration for half-maximal effect: < 4 ug/mL
Compound 3 gave a limit, no number; the forecaster's own chance of this, stated with the estimate: 60%; the middle value lies beyond the limit too.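

No step among compound 1, compound 2 and compound 3 can be sized, since all three give only a limit and no number: the limit of < 4 ug/mL in this assay, at which 3 of the 3 values shown sit.

The compounds shown leave open where each true value lies in this assay, and so whether the 4-methoxyphenyl, 2-methoxyphenyl and 1,3-thiazol-2-yl arms differ at all.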